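Methyl on the oxetan-3-yl group of compound 2

This account rests on a few compounds, and the source may have more. Where it says the series, first, only, none or still open, it means among the compounds named here.

- compound 1 (`CC(Sc1nc2nn(C3COC3)cc2c(=O)n1-c1ccccc1)c1ccccn1`): 3300 nM
- compound 2 (`CC(Sc1nc2nn(C3COC3)cc2c(=O)n1-c1ccccc1)c1ccccc1`): 7900 nM

In an ADME assay on the whole organism (Mus musculus, strain CD-1) for pharmacokinetics, read by LC-MS, with a stated time of 7 h, at a dose of 10 mg/kg by the intraperitoneal route (a lower number here means less compound in the circulation, a higher number more compound in the circulation at the dose given), compound 2 stands highest of the two, at 7900 nM. Compound 3 (`CC(Sc1nc2nn(C3(C)COC3)cc2c(=O)n1-c1ccccc1)c1ccccc1`) differs from it by methyl in place of hydrogen on a saturated ring carbon. For the measured compounds named here, the only measured step, a 2.4-fold higher number from compound 1 to compound 2 (0.38 log units; beyond the scatter), was modest and concerns phenyl in place of pyridin-2-yl, a different place in the structure. Going by the values given here, no measured step bears directly on this change, so no step beyond the scatter is expected. The estimated step is a 1.1-fold lower number from compound 2 to compound 3 (0.05 log units; within the scatter). Compound 3 is expected at 7000 nM, with an estimated range from 3000 nM to 16000 nM.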

Compound 3, maximal plasma concentration: 7000 nM
The estimate for compound 3 equals the measured number at the digits printed; low and high end bracket the measured number.
By their numbers in this assay, from the lowest: compound 1; then compounds 3 and 2 (each within the scatter of the next).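

In this assay, 3-methyloxetan-3-yl in place of oxetan-3-yl gives a 1.1-fold lower number from compound 2 to compound 3 (0.05 log units; within the scatter) and so this saturated ring carbon takes a methyl with no change beyond the scatter. For the compounds shown here, this is the first reading at this position, as the earlier step concerned phenyl and pyridin-2-yl elsewhere in the structure. Nothing available explains the result.

From the compounds shown here alone, whether an amine or a longer chain on this ring carbon would hold the number stays open. So does whether the methyl reads the same with the pyridin-2-yl group of compound 1.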